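The source may hold more compounds than are shown below. What is called first, only, known or untested is meant among the compounds shown, and "the series" means these compounds.

Compound 3 `O=C(/C=C/c1cccc(NS(=O)(=O)c2ccccc2Cl)c1)c1nc2ccccc2[nH]1` gives the lowest number of the three measured compounds in a functional assay on HCT-116 cells (Homo sapiens) for antiproliferative activity, read by MTT assay, with a stated time of 48 h (a lower number here means a stronger inhibitor, a higher number a weaker inhibitor), namely 987 nM. Compound 1 `Cc1ccc(C(=O)Nc2cccc(/C=C/C(=O)c3nc4ccccc4[nH]3)c2)cc1` gives 1660 nM and compound 2 `COc1cccc(C(=O)Nc2cccc(/C=C/C(=O)c3nc4ccccc4[nH]3)c2)c1` gives 3680 nM; the step of a 1.7-fold lower number from compound 1 to compound 3 (0.23 log units; within the scatter) stays within the scatter, whereas a 3.7-fold lower number from compound 2 to compound 3 (0.57 log units; beyond the scatter) lies beyond it. Compound 4 `Cc1ccc(S(=O)(=O)Nc2cccc(/C=C/C(=O)c3nc4ccccc4[nH]3)c2)cc1C` differs from compound 3 by 3,4-dimethylphenyl in place of 2-chlorophenyl on a sulfonyl sulfur. Among the measured compounds shown here, no measured step swaps one ring for another on the sulfonyl sulfur; the only step that alters a ring on the amide side, a 2.2-fold higher number from compound 1 to compound 2 (0.35 log units; beyond the scatter), was modest. Compound 4 is therefore expected to show a step of a 1.3-fold higher number from compound 3 to compound 4 (0.12 log units; within the scatter), small and of uncertain direction. Compound 4 is estimated at 1300 nM, within 500 nM to 3500 nM.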

Compound 4, half-maximal inhibitory concentration: 2230 nM
Estimate against measurement, compound 4: 1.7-fold (0.23 log units) below; low and high end bracket the measured number.
By their numbers in this assay, from the lowest: compounds 3, 1, 4 and 2 (each within the scatter of the next, the first and the last beyond it).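

On the sulfonyl sulfur, 3,4-dimethylphenyl in place of 2-chlorophenyl gives a 2.3-fold higher number from compound 3 to compound 4 (0.35 log units; beyond the scatter), so this position responds to a change of substituents in this assay. The step is modest, yet it goes beyond the scatter even though both groups carry one six-membered aromatic ring of carbon only. Nothing measured here offers a reason for this step. Going by these compounds, this single swap removes the chlorine and adds two methyl groups, so the share of each remains open. On these data alone, how a plain phenyl ring or a simple methyl group on the sulfonyl sulfur would compare also remains open.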